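The source may hold more compounds than are shown below. What is called first, only, known or untested is meant among the compounds shown, and "the series" means these compounds.

Compounds measured in a functional assay on DA-3 cells for cytotoxicity against DA-3 cell line (Mus musculus), read by MTT assay; a lower number here means a stronger inhibitor, a higher number a weaker inhibitor:
compound 1 `CC(=O)O[C@@H]1OC(=O)[C@](Cc2ccccc2)(C(C)=O)[C@@H]1C`, where compound 1 gives 45000 nM.
compound 2 `CC(=O)O[C@@H]1OC(=O)[C@](OC(C)=O)(C(C)=O)[C@@H]1C`, where compound 2 gives > 50000 nM, which is a limit of the assay and not a number.

Compound 2 thus stands only at the ceiling of this assay, the point where the limit of > 50000 nM in this assay, at which 1 of the 2 values shown sits, sits, and the step of an at least 1.1-fold higher number from compound 1 to compound 2 (0.04 log units; that floor lies within the scatter) touches only its floor. Compound 3 `CC(=O)O[C@@H]1OC(=O)[C@@H](C(C)=O)[C@@H]1C` differs by hydrogen in place of acetoxy on a saturated ring carbon. Among the compounds with values here, the single step touching that carbon, an at least 1.1-fold higher number from compound 1 to compound 2 (0.04 log units; that floor lies within the scatter), was no larger than the scatter, so in this assay no step beyond the scatter is expected. Compound 3 is estimated at 50000 nM, between 20000 nM and 150000 nM, an expected step of a number no higher from compound 2 to compound 3 (the limit leaves the size open).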

Compound 3, half-maximal inhibitory concentration: > 50000 nM
Compound 3: a limit, no number; the forecaster's own chance of this, stated with the estimate: 60%; the middle value sits exactly at the limit.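

In this assay compound 3 gives > 50000 nM, which is a limit of the assay and not a number. Hydrogen in place of benzyl on this saturated ring carbon gives an at least 1.1-fold higher number from compound 1 to compound 3 (0.04 log units; that floor lies within the scatter). The step from compound 2 to compound 3 cannot be read, so no difference between acetoxy and hydrogen at this position can be stated: the limit of > 50000 nM in this assay, at which 2 of the 3 values shown sit.

Going by these compounds, it remains open whether an amine, a carboxylic acid or a longer chain on this ring carbon would give a number clearly lower than that of compound 1, 45000 nM. On these data alone, how far the true values of compound 2 and compound 3 lie past their limits also stays open.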